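The source may hold more compounds than are shown below. What is called first, only, known or untested is meant among the compounds shown, and "the series" means these compounds.

Measured compounds:
compound 1 `COc1ccc([N+](=O)[O-])cc1CSc1nc2cc(NC(=O)NC(C)(C)C)ccc2n1C1CC1`; in an assay on isolated protein for inhibition of Gonadotropin-releasing hormone receptor (Homo sapiens) (a lower number here means a stronger inhibitor, a higher number a weaker inhibitor), compound 1 gives 79 nM
compound 2 `CCn1c(SCc2cc([N+](=O)[O-])ccc2OC)nc2cc(NC(=O)NC(C)(C)C)ccc21`; in this assay compound 2 gives 42 nM
compound 3 `COc1ccc([N+](=O)[O-])cc1CSc1nc2cc(NC(=O)NC(C)(C)C)ccc2n1Cc1ccccn1`; in this assay compound 3 gives 43 nM

Compound 3 holds the second highest of the three numbers. Its nearest neighbour is compound 2 and its furthest is compound 1; a 1.0-fold higher number from compound 2 to compound 3 (0.01 log units; within the scatter) and a 1.8-fold lower number from compound 1 to compound 3 (0.26 log units; within the scatter) are both within the scatter, so no order can be read among the three. The three compounds differ only in the group on the aromatic nitrogen of the shared core, and a 1.9-fold lower number from compound 1 to compound 2 (0.27 log units; within the scatter) is likewise within the scatter.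

Compound 4 `COc1ccc([N+](=O)[O-])cc1CSc1nc2cc(NC(=O)NC(C)(C)C)ccc2n1Cc1ccncc1` is not yet measured. It differs from compound 3 by pyridin-4-yl in place of pyridin-2-yl on a saturated chain carbon bound to an aromatic nitrogen. For the measured compounds named here, no measured pair exchanges one pyridyl for another; the steps that bear on this change are those that alter the group on the aromatic nitrogen, and all three of them stayed within the scatter. For compound 4 the expectation is therefore no step beyond the scatter, a 1.0-fold higher number from compound 3 to compound 4 (0.02 log units; within the scatter). Compound 4 is estimated at 45 nM in this assay, with an expected range from 20 nM to 100 nM.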

Compound 4, half-maximal inhibitory concentration: 47 nM
Estimate against measurement, compound 4: 1.0-fold (0.02 log units) below; the range from low to high includes it.
By their numbers in this assay, from the lowest: compounds 2, 3, 4 and 1 (each within the scatter of the next).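

In this assay, for the compounds shown here, the first exchange of one pyridyl for another on a saturated chain carbon bound to an aromatic nitrogen stays within the scatter (a 1.1-fold higher number from compound 3 to compound 4 (0.04 log units; within the scatter)), so moving from pyridin-2-yl to pyridin-4-yl, with the same atoms joined differently, shows no readable difference. The (pyridin-4-yl)methyl group likewise shows no readable difference from ethyl (a 1.1-fold higher number from compound 2 to compound 4 (0.05 log units; within the scatter)) or from cyclopropyl (a 1.7-fold lower number from compound 1 to compound 4 (0.23 log units; within the scatter)), and all four groups on the aromatic nitrogen now lie within the scatter of one another. No data on these compounds offer an explanation for this result.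

Pyridin-3-yl on the same carbon remains open, as does a longer chain between the aromatic nitrogen and the pyridine. An amine or a carboxylic acid at this place is also untested in the compounds shown, so the limits of this insensitivity are unknown.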